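Benzamido added to the aryl ring of compound 3

The compounds below may be only part of what the source reports. "The series", "measured", "known", "first", "only" and "open" are said of these compounds alone.

Compound 3 `COc1ccc(C2=C(c3cc(OC)c(OC)c(OC)c3)C(=O)C(O)C2)cc1` is the reference point of the series. In an ADME assay on KB cells (Homo sapiens) for cytotoxicity, read by MTT assay, with a stated time of 72 h (a lower number here means a stronger inhibitor, a higher number a weaker inhibitor), compound 3 reaches only the limit of < 1 ug/mL in this assay, at which 1 of the 3 values shown sits, and gives < 1 ug/mL. Compound 1 `COc1ccc(C2=C(c3cc(OC)c(OC)c(OC)c3)C(=O)C(OC(C)=O)C2)cc1` gives 72 ug/mL in this assay, and the step of an at least 72-fold lower number from compound 1 to compound 3 (1.85 log units; beyond the scatter) is counted as an at least 72-fold lower number from compound 1 to compound 3 (1.85 log units; beyond the scatter). Compound 2 `C=CCOc1cc(C2=C(c3cc(OC)c(OC)c(OC)c3)C(=O)C(O)C2)ccc1OC` sits at the other limit (the limit of > 100 ug/mL in this assay, at which 1 of the 3 values shown sits). In this assay compound 2 gives > 100 ug/mL. The step from compound 2 to compound 3 is an at least 100-fold lower number from compound 2 to compound 3 (2.00 log units; beyond the scatter). Compound 3 therefore stands at the strongest end of the numbers shown, with a limit rather than a number, so its true value is not fixed.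

Compound 4 `COc1ccc(C2=C(c3cc(OC)c(OC)c(OC)c3)C(=O)C(O)C2)cc1NC(=O)c1ccccc1` differs from compound 3 by benzamido in place of hydrogen on an aromatic carbon. Among the compounds with values here, of the measured steps, the one from compound 2 to compound 3 bears most directly on it: there a substituent on an aromatic carbon of the same ring, in the same place relative to the methoxy group, was replaced by hydrogen and the number fell by an at least 100-fold lower number from compound 2 to compound 3 (2.00 log units; beyond the scatter). Going the other way, adding a substituent at that place, a large rise in the number is expected in this assay, though benzamido is not allyloxy, so the size is uncertain. Compound 4 is expected to give 20 ug/mL, within 2 ug/mL to 100 ug/mL, an expected step of an at least 20-fold higher number from compound 3 to compound 4 (1.30 log units; beyond the scatter).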

Compound 4, half-maximal inhibitory concentration: > 100 ug/mL
Compound 4 gave a limit, no number; the forecaster's own chance of this, stated with the estimate: 25%; middle value at least 5.0-fold (0.69 log units) away from the limit.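

In this assay, the step of an at least 100-fold higher number from compound 3 to compound 4 (2.00 log units; beyond the scatter) shows that the large loss at this place, on an aromatic carbon ortho to a methoxy group, is not confined to allyloxy: benzamido, joined to the ring through its nitrogen and carrying a six-membered aromatic ring of its own, also gives it, and among the compounds shown only hydrogen at this place goes with a low number. Compound 4 gives no number, only a limit, and it shares that limit with compound 2: the limit of > 100 ug/mL in this assay, at which 2 of the 4 values shown sit. The step between compound 2 and compound 4 cannot be read, so benzamido and allyloxy cannot be ranked against each other, and the series shows only that both lie far from hydrogen in this assay.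

On these data alone, whether a small group at this place, such as an amine or a single fluorine atom, keeps the number close to that of compound 3 remains open, as does the behaviour of a free carboxylic acid or a shorter amide such as acetamido. With compound 3 and compound 4 both at limits, the true size of their step also remains unfixed.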